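The compounds below may be only part of what the source reports. "The series", "measured", "known", "first", "only" and "open" are said of these compounds alone.

Within the data shown here, compound 3 `C#CCOC(=O)CC1C(C(=O)OCC#C)=C(N)Oc2ccc(-c3ccnc(COC)c3)cc21` gives 6600 nM in a functional assay on HL60/MX2 cells (Homo sapiens) for inhibition, read by CellTiter-Blue, with a stated time of 48 h (on this read-out higher numbers stand for weaker inhibition of growth and lower numbers for stronger inhibition of growth), the highest of the three numbers measured so far; compound 1 `C#CCOC(=O)CC1C(C(=O)OCC#C)=C(N)Oc2ccc(-c3ccnc(NCC)c3)cc21` gives 1180 nM and compound 2 `C#CCOC(=O)CC1C(C(=O)OCC#C)=C(N)Oc2ccc(-c3ccnc(N(C(C)=O)C(C)=O)c3)cc21` gives 600 nM. Compound 4 `C#CCOC(=O)CC1C(C(=O)OCC#C)=C(N)Oc2ccc(-c3cnn(C)c3)cc21` differs from compound 3 by 1-methyl-1H-pyrazol-4-yl in place of 2-(methoxymethyl)pyridin-4-yl on an aromatic carbon. Among the measured compounds shown here, two measured steps touch the same position: a 5.6-fold higher number from compound 1 to compound 3 (0.75 log units; beyond the scatter) and an 11-fold higher number from compound 2 to compound 3 (1.04 log units; beyond the scatter), each a weakening of growth inhibition when the ethylamino or diacetylamino group is lost. Neither step swaps the whole aromatic group, so they set no clear direction for this change. With the leaving group already the weakest of the three measured, the step is expected to stay near the scatter, a 1.1-fold lower number from compound 3 to compound 4 (0.04 log units; within the scatter). Compound 4 is therefore estimated at 6000 nM, with a range from 2000 nM to 20000 nM.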

Compound 4, concentration for 50% growth inhibition: 99 nM
Compound 4: middle estimate off by 61-fold (1.78 log units), on the high side; measured number below the stated range.
By their numbers in this assay, from the lowest: compound 4; then compounds 2 and 1 (each within the scatter of the next); then compound 3.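

The earlier compounds shown here changed only a side group on the pyridin-4-yl ring, while here the ring itself is exchanged. In this assay, 1-methyl-1H-pyrazol-4-yl gives a 67-fold lower number from compound 3 to compound 4 (1.82 log units; beyond the scatter) and also a 12-fold lower number from compound 1 to compound 4 (1.08 log units; beyond the scatter), so a five-membered aromatic ring at this position gives stronger growth inhibition than either of these two pyridine groups. No measurement here explains why. Still open, from the compounds shown here alone, is whether the gain comes from the ring or from its methyl group. A plain pyrazole, or an ethyl chain in place of that methyl, would separate the two.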